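The source may report more compounds than this note shows. Statements on the series, on what has been measured and on what is new or still open speak of the compounds shown alone.

compound 1 `CCn1ccnc1/C=C/C(=O)/C=C/c1coc2ccccc2c1=O`: 1800 nM
compound 2 `CCC(C)n1ccnc1/C=C/C(=O)/C=C/c1coc2ccccc2c1=O`: 1800 nM

In a functional assay on PC-3 cells (Homo sapiens) for cytotoxicity, read by WST assay, with a stated time of 3 days (a higher number here means a weaker inhibitor, a lower number a stronger inhibitor), compound 2 gives 1800 nM, level with compound 1 at 1800 nM. The next structure, compound 3 `CC(C)CCn1ccnc1/C=C/C(=O)/C=C/c1coc2ccccc2c1=O`, keeps the shared core and alters only the side chain: isopentyl in place of sec-butyl on an aromatic nitrogen.

For the measured compounds named here, only one measured step bears on this change. It also alters the chain on that nitrogen, and it is no change at the digits printed from compound 1 to compound 2 (within the scatter). Enlarging the chain there left the reading unmoved in that single case, so no shift beyond the scatter is expected for compound 3, and no direction can be favoured. One step is thin evidence, so the range stays wide. The expected step is no change at the digits printed from compound 2 to compound 3 (within the scatter). For compound 3 the estimated value is 1800 nM, with an expected range from 800 nM to 4000 nM.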

Compound 3, half-maximal inhibitory concentration: 3600 nM
Compound 3: the middle estimate sits 2.0-fold (0.30 log units) below what was measured; low and high end bracket the measured number.
By their numbers in this assay, from the lowest: compounds 1, 2 and 3 (each within the scatter of the next).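

Compound 3 carries the largest chain so far on this aromatic nitrogen, and in this assay the exchange of sec-butyl for isopentyl gives a 2.0-fold higher number from compound 2 to compound 3 (0.30 log units; within the scatter) while the comparison with the ethyl group gives a 2.0-fold higher number from compound 1 to compound 3 (0.30 log units; within the scatter) so even the widest gap among these three compounds stays inside normal repeat variation. Ethyl, sec-butyl and isopentyl therefore all read alike here, which extends the single earlier step to a second, differently shaped chain and shows that this position accepts all three in this cell assay. No supporting measurement is available to explain these readings.

The compounds shown leave open whether a much longer chain, such as octyl, would shift the reading beyond the scatter. They also leave open what a benzyl group, or a chain ending in an amine or a carboxylic acid, would do at this nitrogen.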